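Toward compound 4: swapping the side arm on the shared core

This account rests on a few compounds, and the source may have more. Where it says the series, first, only, none or still open, it means among the compounds named here.

Compound 1: `Cc1cc(C(=O)O)ccc1CN1CCC[C@H](O[C@H](CO)c2ccnc(Cl)c2)[C@@H]1c1ccccc1`, 50000 nM
Compound 2: `Cc1cc(C(=O)O)ccc1CN1CCC[C@H](OC(c2cc(Cl)cc(Cl)c2)C(C)(C)O)[C@@H]1c1ccccc1`, 17000 nM
Compound 3: `Cc1cc(C(=O)O)ccc1CN1CC[C@H](OC(CO)c2cc(Cl)cc(Cl)c2)[C@@H]1c1ccccc1`, 133000 nM

Of the compounds shown here, three on the shared core have been measured in an assay on isolated protein for activation of cGMP-dependent protein kinase 1 (Homo sapiens), read by ADP-Glo, with stated times of 30 min and 2 h, in the presence of a further agent that is not named here; on this read-out higher numbers stand for an effect only at larger amounts of compound and lower numbers for an effect already at smaller amounts. Compound 1 gives 50000 nM in this assay, which places it second highest of the three numbers: compound 3 stands nearest with a higher number, beyond the scatter, and compound 2 furthest with a lower number, also beyond the scatter. No pair among these three differs in one place only, so nothing can be said about a single step between measured compounds.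

Compound 4, `Cc1cc(C(=O)O)ccc1CN1CCC[C@H](O[C@H](CF)c2cc(Cl)cc(Cl)c2)[C@@H]1c1ccccc1`, is not yet measured. It differs from compound 1 by a group of 11 heavy atoms (8 carbon, 1 fluorine, 2 chlorine; one six-membered aromatic ring of carbon only) in place of a group of 10 heavy atoms (7 carbon, 1 nitrogen, 1 oxygen, 1 chlorine; one six-membered aromatic ring with 1 hetero atom), on an oxygen on a saturated carbon. The entering group carries fluorine and two chlorines and no hydrogen-bond donor or acceptor, while the leaving group carried one donor and two acceptors.

For the measured compounds named here, with no single step to lean on, the size of the step to be expected is uncertain. Since compound 2, which also carries a six-membered aromatic ring of carbon only with two chlorines, gives 17000 nM, a somewhat lower number than compound 1 is expected for compound 4, as the step of a 2.0-fold lower number from compound 1 to compound 4 (0.30 log units; within the scatter). The estimate for compound 4 in this assay is 25000 nM, with a range from 8000 nM to 80000 nM.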

Compound 4, half-maximal effective concentration: 9100 nM
The estimate for compound 4 lay 2.7-fold (0.44 log units) above the measured number, within the range that was stated.
By their numbers in this assay, from the lowest: compounds 4 and 2 (each within the scatter of the next); then compound 1; then compound 3.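

On an oxygen on a saturated carbon, the group of 11 heavy atoms with one six-membered aromatic ring of carbon only, in place of the group of 10 heavy atoms with one six-membered aromatic ring with 1 hetero atom, gives in this assay a 5.5-fold lower number from compound 1 to compound 4 (0.74 log units; beyond the scatter), the first single step readable at this place. The entering group has 0 hydrogen-bond donors and 0 hydrogen-bond acceptors, so the donor and acceptors of the leaving group are not required for the lower number in this pair. Nothing available here bears on why the number changed.

The step replaces the aromatic ring and the rest of the group together, so the compounds shown do not separate the share of each. They also leave open how an amine or a longer chain in the entering group would read.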